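Replacing the substituent on an aromatic nitrogen

The source may hold more compounds than are shown below. What is called first, only, known or untested is meant among the compounds shown, and "the series" means these compounds.

In an ADME assay (liver, Mus musculus) for metabolic stability, using microsomes (a lower number here means that the compound disappears faster, a higher number that the compound lasts longer), compound 1 `C=CC(=O)Nc1cccc(CNc2nc(Nc3cn(C)nc3C)ncc2Cl)c1` gives 0.138 h, compound 2 `C=CC(=O)Nc1cccc(CNc2nc(Nc3cnoc3)ncc2Cl)c1` gives 0.0583 h and compound 3 `C=CC(=O)Nc1cccc(CNc2nc(Nc3cnn(CC(=O)N4CCOCC4)c3)ncc2Cl)c1` gives 0.12 h. Compound 3 lies within the scatter of compound 1 and beyond the scatter of compound 2, which has the lowest number of the three.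

The next structure is compound 4 `C=CC(=O)Nc1cccc(CNc2nc(Nc3cnn(C(C)(C)COC)c3)ncc2Cl)c1`, which differs from compound 3 as follows: 1-(methoxymethyl)-1-methylethyl in place of ((morpholin-4-yl)carbonyl)methyl on an aromatic nitrogen. For the measured compounds named here, no measured step covers this replacement. Going by the values given here, the only step available, a 2.4-fold lower number from compound 1 to compound 2 (0.37 log units; beyond the scatter), is modest and concerns a different exchange, 1,2-oxazol-4-yl in place of 1,3-dimethyl-1H-pyrazol-4-yl, so it offers only a rough guide to size. On these data alone, on that basis, no step beyond the scatter is expected, and the direction remains open. The expected change is a 1.2-fold lower number from compound 3 to compound 4 (0.08 log units; within the scatter), which stays within the scatter. For compound 4 the estimated value is 0.1 h, with an expected range of 0.04 h to 0.22 h.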

Compound 4, half-life: 0.03 h
Beside the measured number, compound 4's estimate is 3.3-fold (0.52 log units) above it; measured number outside the range, below it.
By their numbers in this assay, from the lowest: compounds 4 and 2 (each within the scatter of the next); then compounds 3 and 1 (each within the scatter of the next).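

In this assay the exchange of ((morpholin-4-yl)carbonyl)methyl for 1-(methoxymethyl)-1-methylethyl gives a 4.0-fold lower number from compound 3 to compound 4 (0.60 log units; beyond the scatter) and so moves the number beyond the scatter. Unlike the earlier step, which replaced the whole group on the nitrogen of the shared core, this one keeps the five-membered aromatic ring with 2 nitrogen and changes only the substituent on its aromatic nitrogen, so this position alone is enough to alter the half-life. Nothing measured here explains the lower number of compound 4.

The compounds shown leave open which part of the exchange matters, since the ring, the carbonyl and the heavy-atom count all change together. A piperidin-4-yl amine or a carboxymethyl group on the same aromatic nitrogen would extend the comparison at this position.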